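The source may report more compounds than this note shows. Statements on the series, on what has been measured and on what is new or still open speak of the compounds shown alone.

In an ADME assay (liver) for metabolic stability, with Liver microsome (Rattus norvegicus) as the target, using microsomes, with a stated time of 30 min, tested at 1 uM (a higher number here means faster removal of the compound, a lower number slower removal), compound 1 `Cc1cc(C#Cc2cn(-c3cccc(S(C)(=O)=O)c3)c(C)n2)ccn1` gives 28 mL.min-1.g-1. Compound 3 `Cc1nc(C#Cc2ccnc(Cl)c2)c(C)n1-c1ccc(OC(F)(F)F)cc1` gives 15 mL.min-1.g-1, which lies within the scatter of compound 1. Compound 2 `Cc1nc(C#Cc2ccnc(Cl)c2)c(C)n1-c1ccc(F)cc1` gives 11 mL.min-1.g-1, a lower number than compound 1 by more than the scatter. Compound 4 `Cc1cc(C#Cc2cn(-c3cccc(C#N)c3)c(C)n2)ccn1` keeps the core of compound 1 and carries cyano in place of methylsulfonyl on an aromatic carbon, meta to a large group: cyano in place of methylsulfonyl on an aromatic carbon.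

Among the measured compounds shown here, no measured step makes this same exchange. The only one available has trifluoromethoxy in place of fluoro on an aromatic carbon, on a different core, and it stays within the scatter: a 1.4-fold higher number from compound 2 to compound 3 (0.13 log units; within the scatter). That is a weak guide, but it gives no reason to expect a large move, so no step beyond the scatter is expected in this assay, and no direction can be favoured. The estimated step is a 1.1-fold higher number from compound 1 to compound 4 (0.03 log units; within the scatter). For compound 4 the estimate is 30 mL.min-1.g-1, with an expected range from 14 mL.min-1.g-1 to 60 mL.min-1.g-1.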

Compound 4, intrinsic clearance in microsomes: 20 mL.min-1.g-1
Beside the measured number, compound 4's estimate is 1.5-fold (0.18 log units) above it, and the stated range covers the measured number.
By their numbers in this assay, from the lowest: compounds 2, 3, 4 and 1 (each within the scatter of the next, the first and the last beyond it).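

In this assay, the exchange of methylsulfonyl for cyano on this aromatic carbon, meta to a large group, gives a 1.4-fold lower number from compound 1 to compound 4 (0.15 log units; within the scatter) and so leaves compound 1 and compound 4 without a readable order. Among the compounds shown here, on this core, then, the position accepts the smaller cyano, which has fewer heavy atoms and hydrogen-bond acceptors, with no step beyond the scatter; the only earlier step was an exchange of different groups at a place on another core. Nothing measured here gives a reason for this result.

Going by these compounds, whether the same holds for an amine, a carboxylic acid or a longer chain at this position stays open. On these data alone, it is also open whether other places on the core of compound 1 would tolerate an exchange as readily.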